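Benzyloxy for isobutoxy on the shared core: estimate for compound 3

This account rests on a few compounds, and the source may have more. Where it says the series, first, only, none or still open, it means among the compounds named here.

Two compounds of this series have numbers. Compound 1 `CCCN(CCC)c1nc(C(F)(F)F)ccc1CNC(=O)Nc1cccc2[nH]c(=O)ccc12` gives 5.21 nM in an assay on HEK cells for antagonist activity at transient receptor potential cation channel subfamily V member 1 (Homo sapiens), read by FLIPR (on this read-out lower numbers stand for stronger inhibition and higher numbers for weaker inhibition), and compound 2 `CC(C)COc1nc(C(F)(F)F)ccc1CNC(=O)Nc1cccc2[nH]c(=O)ccc12` gives 2.6 nM in the same assay. The one measured step, a 2.0-fold lower number from compound 1 to compound 2 (0.30 log units; within the scatter), is within the scatter, so compound 2 and compound 1 sit together on the numbers shown and neither can be called stronger than the other.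

Compound 3 `O=C(NCc1ccc(C(F)(F)F)nc1OCc1ccccc1)Nc1cccc2[nH]c(=O)ccc12` is not yet measured. Its change from compound 2 is phenyl in place of isopropyl on a saturated chain carbon bound to an oxygen on an aromatic ring. Among the compounds with values here, no measured step touches the saturated chain carbon bound to the oxygen on the aromatic ring; the only step known, from dipropylamino to isobutoxy on the aromatic carbon, lies within the scatter and offers no direction for the isopropyl to phenyl exchange. The expectation is therefore a step of no size beyond the scatter, that is a 1.3-fold higher number from compound 2 to compound 3 (0.13 log units; within the scatter), with a wide range because the data give no guidance for this change.

Compound 3 is estimated to give 3.5 nM in this assay, between 1 nM and 15 nM.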

Compound 3, half-maximal inhibitory concentration: 1.2 nM
For compound 3 the middle estimate is 2.9-fold (0.46 log units) above the measured one; the range from low to high includes it.
By their numbers in this assay, from the lowest: compound 3; then compounds 2 and 1 (each within the scatter of the next).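

On the saturated chain carbon bound to an oxygen on an aromatic ring, phenyl in place of isopropyl gives in this assay a 2.2-fold lower number from compound 2 to compound 3 (0.34 log units; beyond the scatter) and so shows that the number responds to the group at this position, which the step between compound 1 and compound 2, within the scatter, could not show. The remaining pair reads a 4.3-fold lower number from compound 1 to compound 3 (0.64 log units; beyond the scatter) and leaves compound 3 with the lowest number of the three, both of its steps lying beyond the scatter, so a six-membered aromatic ring of carbon only is accepted here with no loss on this read-out. Nothing at hand says why this exchange moves the number in this direction.

From the compounds shown here alone, it remains open whether the aromatic ring itself or simply the larger group carries the step, a question that a cyclohexyl group in place of the phenyl would separate. Also open, going by these compounds, are a longer chain such as phenethoxy, a fluorine or a methoxy group on the phenyl, and an amine nitrogen in place of the oxygen that carries the benzyl.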